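The source may report more compounds than this note shows. Statements on the series, on what has been measured and on what is new or still open speak of the compounds shown alone.

Compound 1 `CCC(C)n1ccc2cc(/C(C)=C/C(=O)Nc3ccccc3OCCCC(=O)O)ccc21` gives 67 nM in an assay on Prostate gland for inhibition of steroid 5-alpha-reductase (Rattus norvegicus) (on this read-out higher numbers stand for weaker inhibition and lower numbers for stronger inhibition), the lowest of the three numbers in hand. Compound 2 `C/C(=C\C(=O)Nc1ccccc1OCCCC(=O)O)c1ccc2c(ccn2Cc2ccccc2C)c1` gives 69 nM, and the step of a 1.0-fold higher number from compound 1 to compound 2 (0.01 log units; within the scatter) shows the two cannot be told apart. Compound 3 `C/C(=C\C(=O)Nc1ccccc1OCCCC(=O)O)c1ccc2c(ccn2Cc2ccc(C(F)(F)F)cc2)c1` gives 300 nM, with a 4.5-fold higher number from compound 1 to compound 3 (0.65 log units; beyond the scatter) a weakening that is small but real; a 4.3-fold higher number from compound 2 to compound 3 (0.64 log units; beyond the scatter) is of the same size.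

Compound 4 `CCCCC(c1ccccc1)n1ccc2cc(/C(C)=C/C(=O)Nc3ccccc3OCCCC(=O)O)ccc21` is not yet measured. It differs from compound 1 as follows: 1-phenylpentyl in place of sec-butyl on an aromatic nitrogen.

Within the data shown here, two measured steps bear on this: both replace sec-butyl on the aromatic nitrogen with a group carrying a six-membered aromatic ring, one leaving the number unchanged a 1.0-fold higher number from compound 1 to compound 2 (0.01 log units; within the scatter) and one raising it modestly a 4.5-fold higher number from compound 1 to compound 3 (0.65 log units; beyond the scatter). The 1-phenylpentyl group brings more carbon than either benzyl variant, so a step toward weaker inhibition is expected in this assay, of modest size at most, a 2.2-fold higher number from compound 1 to compound 4 (0.35 log units; beyond the scatter).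

Compound 4 is therefore estimated at 150 nM in this assay, with a range of 60 nM to 450 nM.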

Compound 4, half-maximal inhibitory concentration: 9.8 nM
Beside the measured number, compound 4's estimate is 15-fold (1.18 log units) above it, and the stated range ends above it.
By their numbers in this assay, from the lowest: compound 4; then compounds 1 and 2 (each within the scatter of the next); then compound 3.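

In this assay, among these compounds, the aromatic nitrogen accepts the larger 1-phenylpentyl group with a gain rather than a loss, and a 6.8-fold lower number from compound 1 to compound 4 (0.83 log units; beyond the scatter) is the only step from compound 1 toward a lower number. The same group also stands ahead of both benzyl groups, with a 7.0-fold lower number from compound 2 to compound 4 (0.85 log units; beyond the scatter) and a 31-fold lower number from compound 3 to compound 4 (1.49 log units; beyond the scatter) both beyond the scatter, so a six-membered aromatic ring at this position does not by itself set the number: compound 2, compound 3 and compound 4 all carry one, yet their numbers differ. Nothing in hand accounts for these steps.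

The compounds shown do not separate the share of the phenyl ring from that of the saturated chain within 1-phenylpentyl. Also open, on these data alone, is how a longer chain on that carbon, or an amine or a carboxylic acid at the end of the chain, would read in this assay.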